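Chlorine moved to another ring position on the pyrazoline core

This account rests on a few compounds, and the source may have more. Where it says the series, first, only, none or still open, it means among the compounds named here.

Measured compounds:
Compound 1 `O=C(c1cc2ccccc2o1)N1N=C(c2ccccc2)CC1c1ccccc1`: 7.58 ug/mL
Compound 2 `Cc1ccc(C2CC(c3ccccc3)=NN2C(=O)c2cc3ccccc3o2)cc1`: 16.6 ug/mL
Compound 3 `O=C(c1cc2ccccc2o1)N1N=C(c2ccccc2)CC1c1ccc(Cl)cc1`: 5.13 ug/mL

In a functional assay on A2780 cells (Homo sapiens) for antiproliferative activity, read by MTT assay, with a stated time of 72 h (on this read-out lower numbers stand for stronger inhibition and higher numbers for weaker inhibition), compound 2 gives the highest number of the three, that is, the weakest inhibition. Compound 1 sits closest to it, a 2.2-fold higher number from compound 1 to compound 2 (0.34 log units; beyond the scatter) apart, and compound 3 is furthest away, a 3.2-fold lower number from compound 2 to compound 3 (0.51 log units; beyond the scatter).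

Compound 4 `O=C(c1cc2ccccc2o1)N1N=C(c2ccccc2)CC1c1ccccc1Cl` has not been measured. It differs from compound 2 in one place: 2-chlorophenyl in place of 4-methylphenyl on a saturated ring carbon.

Among the compounds with values here, two measured steps bear on this change. Going from compound 2 back to the bare phenyl of compound 1 already lowers the number, as a 2.2-fold higher number from compound 1 to compound 2 (0.34 log units; beyond the scatter) read in reverse shows. Putting chloro where the methyl was, a 3.2-fold lower number from compound 2 to compound 3 (0.51 log units; beyond the scatter), lowers it further. Compound 4 also loses the methyl and gains a chloro, though at a different position of the ring, so the most direct comparison is missing. The expectation is therefore a modest fall in this assay from compound 2, somewhere between the two known steps, with no firm basis for the chlorine's new position beyond that.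

For compound 4 the estimated value in this assay is 7.5 ug/mL, with a range from 3.5 ug/mL to 16 ug/mL, an expected step of a 2.2-fold lower number from compound 2 to compound 4 (0.35 log units; beyond the scatter).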

Compound 4, half-maximal inhibitory concentration: 6.22 ug/mL
The estimate for compound 4 lay 1.2-fold (0.08 log units) above the measured number; low and high end bracket the measured number.
By their numbers in this assay, from the lowest: compounds 3, 4 and 1 (each within the scatter of the next); then compound 2.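

In this assay the swap of 4-methylphenyl for 2-chlorophenyl on the saturated ring carbon gives a 2.7-fold lower number from compound 2 to compound 4 (0.43 log units; beyond the scatter) and so recovers what compound 2 had lost against the bare phenyl of compound 1. The new compound also shows that the place of the chlorine on this ring makes no readable difference here, with a 1.2-fold higher number from compound 3 to compound 4 (0.08 log units; within the scatter) for 2-chlorophenyl in place of 4-chlorophenyl and a 1.2-fold lower number from compound 1 to compound 4 (0.09 log units; within the scatter) for chloro in place of hydrogen, so compounds 1, 3 and 4 cannot be told apart while compound 2 alone stands as the weakest of the four. No measurement of any property of these groups accompanies the numbers, so the reason for this pattern remains unknown.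

Compound 2 is the only case with a methyl on this ring, so one compound carries the whole contrast, and a methyl at the position of the chlorine in compound 4 could show whether the group or its position matters. From the compounds shown here alone, how a methoxy group, an amine or a carboxylic acid on this ring would read in this assay also remains open.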